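Swapping the pyridine substituent on the amine nitrogen

A few compounds are considered here, and "the series" means these few. Any claim that something is new, unique, unknown or untested is made for them only; others in the source may bear on it.

Compound 3 `Cc1cccc(NC[C@@H]2CC3(CC3)CN2C(=O)c2nc(C)sc2-c2ccccc2)n1` is the strongest of the three measured compounds in a functional assay on CHO cells for antagonist activity at Orexin/Hypocretin receptor type 1 (Homo sapiens), read by FLIPR and calcium flux (on this read-out lower numbers stand for lower potency and higher numbers for higher potency (the scale is a negative logarithm)), where compound 3 gives 7.3. Compound 2 `Cc1nc(C(=O)N2CC3(CC3)C[C@H]2CNc2ncc(Cl)cn2)c(-c2ccccc2)s1` reaches 6.8, and compound 1 `Cc1ccnc(NC[C@@H]2CC3(CC3)CN2C(=O)c2nc(C)sc2-c2ccccc2)n1` reaches 6.1. Compound 4 `Cc1nc(C(=O)N2CC3(CC3)C[C@H]2CNc2cc(C(F)(F)F)ccn2)c(-c2ccccc2)s1` differs from compound 3 in one place: 4-(trifluoromethyl)pyridin-2-yl in place of 6-methylpyridin-2-yl on an amine nitrogen. For the measured compounds named here, no measured pair shows this exact exchange, but the ring changes on the same amine nitrogen, a number 0.70 log units higher from compound 1 to compound 2 (beyond the scatter), a number 0.50 log units higher from compound 2 to compound 3 (beyond the scatter) and a number 1.20 log units higher from compound 1 to compound 3 (beyond the scatter), show that this position moves potency well beyond the scatter. With the best ring so far left behind, compound 4 is expected to drop modestly, a number 0.40 log units lower from compound 3 to compound 4 (beyond the scatter), giving an estimated 6.9 with a range from 6.2 to 7.6.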

Compound 4, negative logarithm of the antagonist equilibrium constant: 8.2
Beside the measured number, compound 4's estimate is 1.30 log units below it; measured number above the stated range.
By their numbers in this assay, from the lowest: compound 1; then compound 2; then compound 3; then compound 4.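

The 4-(trifluoromethyl)pyridin-2-yl group makes compound 4 the strongest of the four in this assay, and it surpasses the previous best ring (a number 0.90 log units higher from compound 3 to compound 4 (beyond the scatter)). Against the two pyrimidine groups the gain is larger (a number 1.40 log units higher from compound 2 to compound 4 (beyond the scatter)) and larger still (a number 2.10 log units higher from compound 1 to compound 4 (beyond the scatter)), so the group on this amine nitrogen spans a wider range of potency than the first three compounds showed. Nothing available here explains the rise. Still open, from the compounds shown here alone, is whether a nitrile or a methoxy group in place of the trifluoromethyl would keep this potency.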